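The source may report more compounds than this note shows. Statements on the series, on what has been measured and on what is new or still open speak of the compounds shown alone.

Measured compounds:
- compound 1, `COc1cc(Nc2ncccc2-c2n[nH]c(Nc3ccccc3)n2)cc(OC)c1`, giving 22%
- compound 2, `COc1cc(Nc2ncccc2-c2n[nH]c(Nc3cc(Cl)cc(Cl)c3)n2)cc(OC)c1`, giving "not determined" (no result reported)

Two compounds share one core. In a functional assay on A-431 cells (Homo sapiens), tested at 0.1 uM (on this read-out higher numbers stand for more inhibition at the one concentration tested (going by the name of the read-out) and lower numbers for less inhibition), compound 1 gives 22%, a modest read-out at the single concentration tested. Compound 2 carries a 3,5-dichlorophenyl on the nitrogen instead of a plain phenyl, but for compound 2 no number was reported in this assay, so nothing can be said about where it stands or about the size of the step from compound 1 to compound 2.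

Compound 3, `COc1cc(Nc2ncccc2-c2n[nH]c(Nc3ccc4c(c3)OCCO4)n2)cc(OC)c1`, is not yet measured. It differs from compound 2 in one place: 2,3-dihydro-1,4-benzodioxin-6-yl in place of 3,5-dichlorophenyl on a nitrogen on an aromatic ring. Without any number for compound 2 there is no measured anchor for this change, so the expectation can rest only on compound 1 and its value of 22%. Under this uncertainty no step beyond the usual scatter is assumed in either direction.

Compound 3 is therefore expected to give about 22% in this assay, with a range from 0% to 50%.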

Compound 3, a percentage reported as inhibition, at one concentration (the size of the read-out at that concentration, not a potency): 83%
Estimate against measurement, compound 3: 61 percentage points below; measured number outside the range, above it.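

In this assay, putting 2,3-dihydro-1,4-benzodioxin-6-yl in place of phenyl on the nitrogen gives a number 61 percentage points higher from compound 1 to compound 3 (beyond the scatter). Among these compounds, with a single number, the earlier compounds could not show whether the group at this position matters in this assay; this pair shows that changing it can move the read-out well beyond the usual scatter, although this is a read-out at one concentration and not a potency. Nothing shown here explains why the new group gives so much more inhibition.

The step from compound 2 to compound 3 cannot be read, so the comparison between 3,5-dichlorophenyl and 2,3-dihydro-1,4-benzodioxin-6-yl stays empty, and the effect of this change rests on the phenyl of compound 1 alone. The compounds shown also leave open whether the closed ring holding the two oxygens is needed, or whether a phenyl carrying two separate methoxy groups on this nitrogen would give a similar read-out.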